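Swapping the chloro for a methoxy on the benzyl ring

This account rests on a few compounds, and the source may have more. Where it says the series, first, only, none or still open, it means among the compounds named here.

Measured so far:
Compound 1 `COc1cccc(OC)c1OCCNCCOc1ccccc1OCc1ccccc1` gives 0.537 nM in an assay on CHO cells for displacement of a labelled ligand from Alpha-1B adrenergic receptor (Homo sapiens); a lower number here means a stronger inhibitor, a higher number a weaker inhibitor.
Compound 2 `COc1cccc(OC)c1OCCNCCOc1ccccc1OCc1ccc(Cl)cc1` gives 1 nM.
Compound 3 `COc1ccccc1COc1ccccc1OCCNCCOc1c(OC)cccc1OC` gives 6.31 nM.

Compound 2 has the second highest of the three numbers: its nearest neighbour is compound 1, at a 1.9-fold higher number from compound 1 to compound 2 (0.27 log units; within the scatter), and its furthest is compound 3, at a 6.3-fold higher number from compound 2 to compound 3 (0.80 log units; beyond the scatter). Compound 4 `COc1cccc(COc2ccccc2OCCNCCOc2c(OC)cccc2OC)c1` has not yet been measured. The change from compound 2 to compound 4 is 3-methoxyphenyl in place of 4-chlorophenyl on a saturated chain carbon bound to an oxygen on an aromatic ring.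

Within the data shown here, two measured steps bear on this. The closest is the step from compound 2 to compound 3, which also replaces 4-chlorophenyl with a methoxyphenyl, only with the methoxy at a different place, and gives a 6.3-fold higher number from compound 2 to compound 3 (0.80 log units; beyond the scatter). A methoxy entering elsewhere gives a 12-fold higher number from compound 1 to compound 3 (1.07 log units; beyond the scatter), a large weakening. Both point the same way, so compound 4 is expected to give a higher number than compound 2, with a step estimated at a 3.0-fold higher number from compound 2 to compound 4 (0.48 log units; beyond the scatter). Compound 4 is therefore estimated at 3 nM, with a range from 0.9 nM to 10 nM.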

Compound 4, inhibition constant: 2 nM
For compound 4 the middle estimate is 1.5-fold (0.18 log units) above the measured one; low and high end bracket the measured number.
By their numbers in this assay, from the lowest: compounds 1, 2 and 4 (each within the scatter of the next, the first and the last beyond it); then compound 3.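

In this assay the place of the methoxy on this ring matters, as the 3-methoxyphenyl group in place of the 2-methoxyphenyl group gives a 3.2-fold lower number from compound 3 to compound 4 (0.50 log units; beyond the scatter) and so recovers part of what compound 3 gave up. The exchange of 4-chlorophenyl for 3-methoxyphenyl gives a 2.0-fold higher number from compound 2 to compound 4 (0.30 log units; within the scatter) and stays within the usual scatter, so these two groups cannot be told apart in this assay. Adding the methoxy to the plain ring at this place still gives a 3.7-fold higher number from compound 1 to compound 4 (0.57 log units; beyond the scatter), a modest weakening, and nothing available explains these differences.

From the compounds shown here alone, whether a 4-methoxyphenyl group would sit with compound 4 or with compound 3 stays open. So does the effect of an amine or a carboxylic acid on this ring.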